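Swapping furan for tolyl on the hydrazone arm

This account rests on a few compounds, and the source may have more. Where it says the series, first, only, none or still open, it means among the compounds named here.

Of the compounds shown here, three on a shared core have been tested in a functional assay on MDA-MB-231 cells (Homo sapiens) for cytotoxicity, read by MTT assay, with a stated time of 38 h; a lower number here means a stronger inhibitor, a higher number a weaker inhibitor. Compound 1 `COc1cc(OC)c2c(=O)c(OCC(=O)N/N=C/c3ccc[nH]3)c(-c3cc(OC)c(OC)c(OC)c3)oc2c1` gives 3750 nM. Compound 2 `COc1cc(OC)c2c(=O)c(OCCCCN3CCCCC3)c(-c3cc(OC)c(OC)c(OC)c3)oc2c1` gives 3030 nM. Compound 3 `COc1cc(OC)c2c(=O)c(OCC(=O)N/N=C/c3ccco3)c(-c3cc(OC)c(OC)c(OC)c3)oc2c1` gives 1860 nM. Compound 3 has the lowest of the three numbers, yet the separation is slight: there is a 1.6-fold lower number from compound 2 to compound 3 (0.21 log units; within the scatter) and a 2.0-fold lower number from compound 1 to compound 3 (0.30 log units; within the scatter), both inside the scatter, so the three compounds cannot be ranked against one another on these data.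

Compound 4 `COc1cc(OC)c2c(=O)c(OCC(=O)N/N=C/c3ccc(C)cc3)c(-c3cc(OC)c(OC)c(OC)c3)oc2c1` has not yet been measured in this assay. It differs from compound 3 at the same position that separates compound 1 from compound 3: 4-methylphenyl in place of furan-2-yl on a carbon with a double bond to nitrogen. Within the data shown here, the only measured step at this carbon is a 2.0-fold lower number from compound 1 to compound 3 (0.30 log units; within the scatter), which exchanged one five-membered aromatic ring for another and stayed within the scatter. Among the measured compounds shown here, no measured pair shows an aromatic ring of carbon only at this place, so the data give no direct guide to a six-membered ring there.

On that basis compound 4 is expected to behave much like compound 3, with a 1.3-fold higher number from compound 3 to compound 4 (0.11 log units; within the scatter), a step not expected to exceed the scatter. The estimate for compound 4 is therefore 2400 nM, with a range from 900 nM to 6500 nM.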

Compound 4, half-maximal inhibitory concentration: 4570 nM
For compound 4 the middle estimate is 1.9-fold (0.28 log units) below the measured one; measured number inside the range.
By their numbers in this assay, from the lowest: compounds 3, 2, 1 and 4 (each within the scatter of the next, the first and the last beyond it).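

At the carbon with a double bond to nitrogen, in this assay, 4-methylphenyl in place of furan-2-yl gives a 2.5-fold higher number from compound 3 to compound 4 (0.39 log units; beyond the scatter), a modest step and the first between any two of these compounds to lie beyond the scatter. Among these compounds, it also puts an aromatic ring of carbon only at this place for the first time, and the separation holds only against furan-2-yl: 4-methylphenyl in place of 1H-pyrrol-2-yl gives a 1.2-fold higher number from compound 1 to compound 4 (0.09 log units; within the scatter), and the comparison with the amine chain of compound 2 gives a 1.5-fold higher number from compound 2 to compound 4 (0.18 log units; within the scatter), both within the scatter. Nothing measured for these compounds accounts for the step from compound 3 to compound 4.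

The compounds shown leave open whether this step follows the six-membered ring of carbon only or its methyl, a question that plain phenyl at the same carbon would separate. They also leave open how a thiophen-2-yl ring or a pyridin-3-yl ring would stand against furan-2-yl on this hydrazone arm.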